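The source may hold more compounds than are shown below. What is called first, only, known or untested is meant among the compounds shown, and "the series" means these compounds.

Compound 3 `COc1ccccc1-c1ccc2cnc(Nc3cccc(N4CCN(C)CC4)c3)nn12` gives 0.117 h in an in vitro ADME assay on microsomes from liver (Mus musculus, strain CD1) for metabolic stability, using NADPH, with a stated time of 10 min, tested at 0.5 uM (on this read-out higher numbers stand for a longer-lived compound and lower numbers for a shorter-lived compound), level at the digits shown with compound 1 `COc1ccc(Nc2ncc3ccc(-c4ccccc4OC)n3n2)cc1`, which gives 0.117 h; the two stand together as the highest of the three numbers, while compound 2 `COc1ccccc1-c1ccc2cnc(Nc3ccc(S(=O)(=O)N(C)C)cc3)nn12` gives 0.0833 h, a gap within the scatter. Compound 4 `COc1ccccc1-c1ccc2cnc(Nc3cccc(N4CCN(C[C@H](C)O)CC4)c3)nn12` differs from compound 3 by 1-hydroxyethyl in place of hydrogen on a saturated chain carbon bound to an amine nitrogen in a ring. For the measured compounds named here, the only measured step, a 1.4-fold lower number from compound 1 to compound 2 (0.15 log units; within the scatter), concerns a group on an aromatic carbon and lies within the scatter, so it bears on this new change only loosely. Going by the values given here, no measured pair alters a saturated chain carbon bound to an amine nitrogen in a ring. A step of a 1.0-fold higher number from compound 3 to compound 4 (0.01 log units; within the scatter) is therefore expected, nothing beyond the scatter. The estimate for compound 4 is 0.12 h, with a range from 0.06 h to 0.25 h.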

Compound 4, half-life: 0.0833 h
Estimate against measurement, compound 4: 1.4-fold (0.16 log units) above, within the range that was stated.
By their numbers in this assay, from the lowest: compounds 2, 4, 1 and 3 (each within the scatter of the next).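

Going from 4-methylpiperazin-1-yl to 4-(2-hydroxypropyl)piperazin-1-yl gives a 1.4-fold lower number from compound 3 to compound 4 (0.15 log units; within the scatter) in this assay, the first measured change on a saturated chain carbon bound to an amine nitrogen in a ring. So 1-hydroxyethyl can enter at this place, defined stereocentre included, without moving the half-life beyond the scatter. No available evidence accounts for this result. On these data alone, whether a carboxylic acid, an amine or a longer chain at this place would shift the half-life beyond the scatter stays open. So does how the opposite stereoisomer of the 2-hydroxypropyl group would behave.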